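The source may hold more compounds than are shown below. What is called first, only, known or untested is meant among the compounds shown, and "the series" means these compounds.

In a functional assay on MDA-MB-231 cells (Homo sapiens) for cytotoxicity, with a stated time of 48 h (on this read-out higher numbers stand for weaker inhibition and lower numbers for stronger inhibition), compound 3 `O=[N+]([O-])c1ccc(CN2CCC(n3cc(CC(OCc4cc(-c5cccc(F)c5)no4)c4ccc(Br)cc4)nn3)CC2)cc1` gives 5000 nM, the only actual number among the three results shown. Compound 1 `O=[N+]([O-])c1ccc(CN2CCC(n3cc(CC(OCc4cc(-c5ccc(Br)cc5)no4)c4ccc(Br)cc4)nn3)CC2)cc1` gives only a limit of the assay, > 25000 nM. Compound 2 `COc1ccc(-c2cc(COC(Cc3cn(C4CCN(Cc5ccc([N+](=O)[O-])cc5)CC4)nn3)c3ccc(Br)cc3)on2)cc1` likewise gives only a limit, > 25000 nM. Compound 4 `O=[N+]([O-])c1ccc(CN2CCC(n3cc(CC(OCc4cc(-c5ccccc5F)no4)c4ccc(Br)cc4)nn3)CC2)cc1` differs from compound 3 by 2-fluorophenyl in place of 3-fluorophenyl on an aromatic carbon. Among the compounds with values here, no measured step moves the fluorine around the same ring; the nearest comparisons replace the whole phenyl group, and both an at least 5.0-fold lower number from compound 1 to compound 3 (0.69 log units; beyond the scatter) and an at least 5.0-fold lower number from compound 2 to compound 3 (0.69 log units; beyond the scatter) favour the fluorophenyl compound, although their full size is hidden because of the limit of > 25000 nM in this assay, at which 2 of the 3 values shown sit. With nothing measured on the position of the fluorine, no step beyond the scatter is expected here: no change at the digits printed from compound 3 to compound 4 (within the scatter). Compound 4 is therefore estimated at 5000 nM, somewhere between 2000 nM and 15000 nM.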

Compound 4, half-maximal inhibitory concentration: 4000 nM
Estimate against measurement, compound 4: 1.3-fold (0.10 log units) above; the measured number falls inside the stated range.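

Moving the fluorine from 3-fluorophenyl to 2-fluorophenyl at this place on the ring leaves the result within the scatter, with a 1.3-fold lower number from compound 3 to compound 4 (0.10 log units; within the scatter). Compound 4 also stands clear of the compounds carrying 4-methoxyphenyl and 4-bromophenyl, with an at least 6.2-fold lower number from compound 2 to compound 4 (0.79 log units; beyond the scatter) and an at least 6.2-fold lower number from compound 1 to compound 4 (0.79 log units; beyond the scatter). The full size of these last two steps stays hidden because each starts from a limit, not a number: the limit of > 25000 nM in this assay, at which 2 of the 4 values shown sit.

Open, on these data alone, is how 4-fluorophenyl or plain phenyl would compare here. Those two groups would show whether the fluorine's place or the fluorine itself separates these compounds.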